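Swapping a Methyl for a Piperidinyl Group on the Amide Chain

The source may report more compounds than this note shows. Statements on the series, on what has been measured and on what is new or still open speak of the compounds shown alone.

Of the compounds shown here, three have so far been measured in a functional assay on PC-3 cells (Homo sapiens) for cytotoxicity, read by MTT assay, with a stated time of 48 h; a higher number here means a weaker inhibitor, a lower number a stronger inhibitor. Compound 1 `CC1=NN(C(=O)/C=C/c2ccccc2)C(c2ccccc2O)C1` gives 42000 nM, compound 2 `CC(=O)Oc1ccccc1C1CC(C)=NN1C(=O)CCl` gives 3580 nM, and compound 3 `CCC(=O)N1N=C(c2cc3ccccc3oc2=O)CC1c1ccccc1` gives 4370 nM. On these numbers compound 3 stands second highest of the three. Its nearest neighbour is compound 2, whose number lies within the usual scatter of its own, so no order can be claimed between them. Compound 1, the furthest, has a higher number well beyond the scatter, and is therefore the weaker inhibitor of that pair.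

Compound 4 `CCN(CC)C1CCN(CC(=O)N2N=C(c3cc4ccccc4oc3=O)CC2c2ccccc2)CC1` has not yet been measured. It differs from compound 3 in one place: 4-(diethylamino)piperidin-1-yl in place of methyl on a saturated chain carbon bound to a carbonyl carbon. For the measured compounds named here, no two measured compounds differ in a single place, so there is no measured step to lean on here. The expected step is a 1.5-fold lower number from compound 3 to compound 4 (0.16 log units; within the scatter), small and quite possibly none beyond the scatter, in either direction. Compound 4 is therefore estimated at 3000 nM, with a range from 900 nM to 10000 nM.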

Compound 4, half-maximal inhibitory concentration: 26100 nM
For compound 4 the middle estimate is 8.7-fold (0.94 log units) below the measured one; the whole stated range lies below it.
By their numbers in this assay, from the lowest: compounds 2 and 3 (each within the scatter of the next); then compounds 4 and 1 (each within the scatter of the next).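

For the compounds shown here, this is the first measured step at this position, on a saturated chain carbon bound to a carbonyl carbon. In this assay, placing 4-(diethylamino)piperidin-1-yl there in place of methyl gives a 6.0-fold higher number from compound 3 to compound 4 (0.78 log units; beyond the scatter), so the position does not tolerate every change: this much larger group, with its six-membered ring and two nitrogens, goes with a weaker inhibitor. No measurement available here accounts for the change.

The compounds shown leave open whether the piperidine ring or the diethylamino group on it goes with the higher number, since the two enter together in this single step. A plain piperidine ring without the diethylamino group, or a small dimethylamine on the same carbon, would help to separate the two parts.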